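The source may hold more compounds than are shown below. What is called first, only, known or untested is meant among the compounds shown, and "the series" means these compounds.

Compound 3 `Cn1nc(N)c2c(=O)[nH]c(-c3ccccc3)cc21` gives 37% in an assay on isolated protein for inhibition of MAP kinase-activated protein kinase 2 (Homo sapiens), read by mobility shift assay, tested at 30 uM (on this read-out higher numbers stand for more inhibition at the one concentration tested (going by the name of the read-out) and lower numbers for less inhibition), the second highest of the three values. Compound 2 `Cc1cc2c(c(N)nn2C)c(=O)[nH]1` gives 29% in this assay, and the step of a number 8 percentage points higher from compound 2 to compound 3 (within the scatter) lies within the scatter. Compound 1 `COc1ccc(-c2cc3[nH]nc(N)c3c(=O)[nH]2)cc1` gives 59% in this assay, beyond the scatter above compound 3. Compound 4 `COc1ccc(-c2cc3c(c(N)nn3C)c(=O)[nH]2)cc1` differs from compound 3 by methoxy in place of hydrogen on an aromatic carbon. Among the measured compounds shown here, no measured step matches this change; compound 1 and compound 3 differ in more than one place, so their values only hint that a methoxy-bearing compound may score somewhat higher. Compound 4 is therefore expected to give about 45% in this assay, within 25% to 65%, a step of a number 8 percentage points higher from compound 3 to compound 4 (within the scatter) that is estimated to lie within the scatter.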

Compound 4, a percentage reported as inhibition, at one concentration (the size of the read-out at that concentration, not a potency): 51%
Compound 4: the middle estimate sits 6 percentage points below what was measured; low and high end bracket the measured number.
By their numbers in this assay, from the lowest: compounds 2 and 3 (each within the scatter of the next); then compounds 4 and 1 (each within the scatter of the next).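

Methoxy para to a large group, on the six-membered aromatic ring of carbon only, gives the only step beyond the scatter among these compounds in this assay, a number 14 percentage points higher from compound 3 to compound 4 (beyond the scatter). With methoxy in place, methyl in place of hydrogen on the aromatic nitrogen stays within the scatter, a number 8 percentage points lower from compound 1 to compound 4 (within the scatter). No evidence bears on the cause of either step. The compounds shown leave open whether an amine, a carboxylic acid or a longer alkoxy chain at this place would give a similar step, and whether methoxy would do so at any other place on that ring.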